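The source may hold more compounds than are shown below. What is called first, only, known or untested is meant among the compounds shown, and "the series" means these compounds.

Compound 2 `O=C(Nc1ccccc1)Nc1ccc(OC(=O)c2ccccc2)cc1` gives the highest of the three numbers seen so far in a functional assay on A549 cells (Homo sapiens) for antiproliferative activity, read by MTT assay, with a stated time of 48 h (on this read-out higher numbers stand for weaker inhibition and lower numbers for stronger inhibition), where compound 2 reaches 81200 nM. Compound 3 `COc1ccc(C(=O)Oc2ccc(NC(=O)Nc3ccccc3)cc2)cc1` gives 60200 nM in this assay, and the step of a 1.3-fold lower number from compound 2 to compound 3 (0.13 log units; within the scatter) stays within the scatter. Among the measured compounds shown here, compound 1 `O=C(Nc1ccc(OC(=O)c2ccccc2)cc1)Nc1ccc(Cl)c(C(F)(F)F)c1`, with chloro and trifluoromethyl on its anilino ring, gives 30100 nM in this assay, a number beyond the scatter from compound 2, though the two differ in more than one place and no single step is counted between them.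

Compound 4 `O=C(Nc1ccc(Cl)cc1)Nc1ccc(OC(=O)c2ccccc2)cc1` differs from compound 2 in one place: chloro in place of hydrogen on an aromatic carbon. For the measured compounds named here, the only counted step, from compound 2 to compound 3, lies within the scatter, and it concerns the benzoate ring rather than the anilino ring. The pair of compound 1 and compound 2 suggests that substitution on the anilino ring can lower the number, but chloro alone is not separated there from trifluoromethyl. A small lowering of the number is therefore expected for compound 4, estimated as a 1.6-fold lower number from compound 2 to compound 4 (0.21 log units; within the scatter). In this assay compound 4 is expected to give about 50000 nM, within a range from 25000 nM to 100000 nM.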

Compound 4, half-maximal inhibitory concentration: 24700 nM
Beside the measured number, compound 4's estimate is 2.0-fold (0.31 log units) above it; measured number below the stated range.
By their numbers in this assay, from the lowest: compounds 4, 1, 3 and 2 (each within the scatter of the next, the first and the last beyond it).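

Among the compounds shown here, the change from phenyl to 4-chlorophenyl is the first single change in this assay to go beyond the scatter, with a 3.3-fold lower number from compound 2 to compound 4 (0.52 log units; beyond the scatter), whereas the methoxy change on the benzoate ring stayed within it. The second step, a 1.2-fold lower number from compound 1 to compound 4 (0.09 log units; within the scatter), stays within the scatter, so once chloro is in place, trifluoromethyl on the same ring adds nothing that can be separated here. Nothing given here explains the effect of chloro at this place.

On these data alone, whether fluoro, methyl or an amine at this same place would match chloro remains open. So does whether chloro on the anilino ring and methoxy on the benzoate ring, which compound 3 carries, would act together in one compound.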